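The source may hold more compounds than are shown below. What is called first, only, known or untested is meant among the compounds shown, and "the series" means these compounds.

In a functional assay on HT-1080 cells (Homo sapiens) for antiproliferative activity, read by MTT assay, with a stated time of 72 h (on this read-out lower numbers stand for stronger inhibition and higher numbers for weaker inhibition), compound 1 `COc1ccc(-c2cc(C(=O)O)sc2-c2cc(OC)c(OC)c(OC)c2)cc1O` gives 11400 nM and compound 2 `COc1ccc(-c2ccsc2-c2cc(OC)c(OC)c(OC)c2)cc1[N+](=O)[O-]` gives 8040 nM, two values within the scatter of each other. Compound 3 `COc1ccc(-c2ccsc2-c2cc(OC)c(OC)c(OC)c2)cc1O` carries hydroxy in place of the nitro of compound 2, on an aromatic carbon ortho to a methoxy group: hydroxy in place of nitro on an aromatic carbon. Within the data shown here, no measured step isolates this change, so its size remains a judgement with wide uncertainty. A large move to a lower number in this assay, beyond the scatter, is expected. The estimated change is a 27-fold lower number from compound 2 to compound 3 (1.43 log units; beyond the scatter). For compound 3 the expected value is 300 nM, with an estimated range of 20 nM to 5000 nM.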

Compound 3, half-maximal inhibitory concentration: 2120 nM
Compound 3: the middle estimate sits 7.1-fold (0.85 log units) below what was measured, and the stated range covers the measured number.
By their numbers in this assay, from the lowest: compound 3; then compounds 2 and 1 (each within the scatter of the next).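

Hydroxy in place of nitro on this aromatic carbon, ortho to a methoxy group, gives the first measured step at this position (a 3.8-fold lower number from compound 2 to compound 3 (0.58 log units; beyond the scatter)). Hydrogen in place of carboxy on an aromatic carbon also moves beyond the scatter (a 5.4-fold lower number from compound 1 to compound 3 (0.73 log units; beyond the scatter)), so compound 3 has the lowest number of the three. Nothing available here accounts for either step.

As far as these compounds go, whether an amine or a fluorine on the same carbon would match hydroxy remains open. So does how an amide or methyl ester would compare with the carboxy group of compound 1.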